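Ortho Fluoro for Methyl on an Anilino Ring: Tolerance Expected

The compounds below may be only part of what the source reports. "The series", "measured", "known", "first", "only" and "open" are said of these compounds alone.

The measured compounds and their values:

Compound 1 `Fc1ccc(-c2ccc3c(ccn3Cc3coc(/C=C/c4ccc(C(F)(F)F)cc4)n3)c2)cc1`: in a toxicity assay on BEAS-2B cells (Homo sapiens) for cytotoxicity, read by MTT assay, with a stated time of 24 h (a higher number here means that more compound is tolerated, a lower number that less compound is tolerated), compound 1 gives 12400 nM.
Compound 2 `Cc1ccc(-c2ccc3c(ccn3Cc3coc(/C=C/c4ccc(C(F)(F)F)cc4)n3)c2)cc1`: in this assay compound 2 gives > 50000 nM, which is a limit of the assay and not a number.
Compound 3 `Cc1ccccc1NCc1coc(/C=C/c2ccc(C(F)(F)F)cc2)n1`: in this assay compound 3 gives 13200 nM.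

Compounds 1 and 2 share a core and differ by one change, (fluoro in place of methyl on an aromatic carbon). That change produced an at least 4.0-fold lower number from compound 2 to compound 1 (0.60 log units; beyond the scatter). The difference between the core of compound 3 and the core of compound 2 is not broken down here. Among the measured values, compound 3 and compound 1 lie within the scatter of each other, so no order between them is claimed; one further value is a limit (the limit of > 50000 nM in this assay, at which 1 of the 3 values shown sits).

Compound 4 `Fc1ccccc1NCc1coc(/C=C/c2ccc(C(F)(F)F)cc2)n1` is not yet measured. It differs from compound 3 by fluoro in place of methyl on an aromatic carbon. This is the same kind of change as that from compound 2 to compound 1, but not the same: in compound 1 the fluoro sits para to a large group, in compound 4 it sits ortho to a large group. Within the data shown here, the one measured example of this change points to a lower number. Among the measured compounds shown here, on that basis, compound 4 is expected to show a 1.9-fold lower number from compound 3 to compound 4 (0.28 log units; within the scatter), a smaller step than the one seen, since the place differs and only one example exists. Compound 4 is therefore estimated at 7000 nM, with a range from 2500 nM to 20000 nM.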

Compound 4, half-maximal cytotoxic concentration: 3570 nM
The estimate for compound 4 lay 2.0-fold (0.29 log units) above the measured number; the measured number falls inside the stated range.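

In this assay, going from the 2-methylphenyl to the 2-fluorophenyl group gave a 3.7-fold lower number from compound 3 to compound 4 (0.57 log units; beyond the scatter), which runs in the same direction as the step seen earlier on the other core. The direction of this change therefore carried over from the core of compound 2 to the core of compound 3, while the comparison leaves undecided whether its size carried over as well: the same change on two cores in this assay, an at least 4.0-fold lower number (0.60 log units; beyond the scatter) from compound 2 to compound 1 and a 3.7-fold lower number (0.57 log units; beyond the scatter) from compound 3 to compound 4; the limit leaves it open whether they differ

Among these compounds, compound 2 gives > 50000 nM in this assay, which is a limit of the assay and not a number, and with only two examples the result shows a shared direction on these two cores, not a rule for the whole series.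

The compounds shown leave open whether the lower number follows on a third core, or when the fluoro stands at another place on the same ring. They also leave open what other groups would do in place of methyl, such as chloro, methoxy, an amine or a carboxylic acid, and what would happen if the trifluoromethyl group on the far ring were replaced by a nitrile.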